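The source may report more compounds than this note shows. Statements on the series, on what has been measured and on what is new or still open speak of the compounds shown alone.

Measured compounds:

- compound 1 `N=C(NCc1ccc(O)cc1)[C@@H]1CCC(=O)N1Cc1ccc(F)cc1` — 35.2%
- compound 2 `COc1ccc(CN2C(=O)CC[C@H]2C(=N)NCc2ccccc2)cc1` — 12.3%

In a functional assay on SH-SY5Y cells (Homo sapiens) for cytotoxicity, read by MTT assay, with stated times of 8 h, 30 min and 12 h, tested at 0.05 uM (on this read-out higher numbers stand for a stronger effect at the one concentration tested and lower numbers for a weaker effect), compound 1 gives 35.2%. Compound 2 stands lowest of the two numbers; its nearest neighbour is compound 1, higher by a margin that lies beyond the scatter. The two compounds differ in more than one place, so their values are taken only as they stand, without a step assigned to any single change.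

Compound 3 `COc1ccc(CN2C(=O)CC[C@H]2C(=N)NCc2ccc(O)cc2)cc1` is not yet measured in this assay. Relative to compound 2 it carries hydroxy in place of hydrogen on an aromatic carbon. As far as these compounds go, the same hydroxy group on the same benzyl position is present in compound 1, whose value of 35.2% is the higher of the two numbers, though compound 1 also differs from compound 2 elsewhere, so the share of that single change is unknown.

For compound 3 an upward step of moderate size is expected, estimated at a number 11.7 percentage points higher from compound 2 to compound 3 (beyond the scatter). Compound 3 is thus estimated at 24%, in a range from 10% to 40%.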

Compound 3, a percentage reported as activity, at one concentration (the size of the read-out at that concentration, not a potency): 16%
Compound 3: middle estimate off by 8 percentage points, on the high side; low and high end bracket the measured number.
By their numbers in this assay, from the lowest: compounds 2 and 3 (each within the scatter of the next); then compound 1.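

In this assay, the change from benzyl to 4-hydroxybenzyl, with the methoxy-substituted aromatic ring held fixed, gives a number 3.7 percentage points higher from compound 2 to compound 3 (within the scatter), so on this read-out the added hydroxy group does not separate the two compounds. Among these compounds, the 4-hydroxybenzyl group alone therefore does not bring compound 3 to the level of compound 1: with that group held constant, methoxy in place of fluoro on the other aromatic ring gives a number 19.2 percentage points lower from compound 1 to compound 3 (beyond the scatter), the only single-place step that lies beyond the scatter. Nothing available bears on why either step has the size it has.

As far as these compounds go, whether hydroxy in place of hydrogen also gives a step within the scatter when fluoro stands on the other aromatic ring remains open, as does the effect of an amine or a carboxylic acid in place of the hydroxy group. With only one concentration per compound, the compounds shown also leave open how these differences would appear at other concentrations.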